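Removing one trifluoromethyl from a urea-bearing aryl group

The compounds below may be only part of what the source reports. "The series", "measured", "known", "first", "only" and "open" are said of these compounds alone.

Measured compounds:
- Compound 1 `O=C(Nc1cccc(-n2cc(-c3ccncc3)c(-c3cc(O)cc(Cl)c3)n2)c1)Nc1ccc(Cl)c(C(F)(F)F)c1` gives -40% in a functional assay on UACC-257 cells (Homo sapiens) for inhibition, read by sulforhodamine B assay, with a stated time of 48 h, tested at 10 uM; a lower number here means a stronger effect, a higher number a weaker effect of the compound at the concentration tested.
- Compound 2 `COc1cc(Cl)cc(-c2nn(-c3cccc(NC(=O)Nc4ccc(Cl)c(C(F)(F)F)c4)c3)cc2-c2ccncc2)c1` gives -25.9% in this assay.
- Compound 3 `COc1cc(Cl)cc(-c2nn(-c3cccc(NC(=O)Nc4cc(C(F)(F)F)cc(C(F)(F)F)c4)c3)cc2-c2ccncc2)c1` gives -25.6% in this assay.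

Compound 3 stands highest of the three numbers, though its gap to compound 2 is within the scatter; only compound 1 lies clearly lower. Among the compounds with values here, the one measured single-place step, a number 14.1 percentage points higher from compound 1 to compound 2 (beyond the scatter), concerns a methyl on an oxygen and does not bear on the present change. Compound 4 `COc1cc(Cl)cc(-c2nn(-c3cccc(NC(=O)Nc4cccc(C(F)(F)F)c4)c3)cc2-c2ccncc2)c1` differs from compound 3 by hydrogen in place of trifluoromethyl on an aromatic carbon. Within the data shown here, with no step of this kind measured, no shift beyond the scatter is expected; the step of a number 3.6 percentage points higher from compound 3 to compound 4 (within the scatter) is an estimate resting only on compound 3. Compound 4 is therefore expected to give about -22%, within -42% to -2%.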

Compound 4, a percentage reported as activity, at one concentration (the size of the read-out at that concentration, not a potency): -11.7%
Estimate against measurement, compound 4: 10.3 percentage points below, within the range that was stated.
By their numbers in this assay, from the lowest: compound 1; then compounds 2 and 3 (each within the scatter of the next); then compound 4.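

In this assay, replacing trifluoromethyl with hydrogen weakens the effect, giving a number 13.9 percentage points higher from compound 3 to compound 4 (beyond the scatter). Replacing chloro with hydrogen moves the number the same way, giving a number 14.2 percentage points higher from compound 2 to compound 4 (beyond the scatter), so for these two groups, the substituent lost from this aromatic ring matters beyond the scatter. The data shown offer no explanation for either shift. From the compounds shown here alone, it remains open whether a nitrile or an amine in place of the trifluoromethyl would preserve the effect. Also open, going by these compounds, is whether the same loss would occur with the hydroxyl of compound 1 in place of the methoxy group.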